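Exchanging the Fused Bicyclic Group on a Chlorinated Core

A few compounds are considered here, and "the series" means these few. Any claim that something is new, unique, unknown or untested is made for them only; others in the source may bear on it.

Compound 1 `CC(=O)N[C@@H]1CCC[C@H](C(=O)Nc2cc(-c3cnn4c3CCCC4)ccn2)C1` gives 33 uL/min in an ADME assay on cells (Hepatocyte, Rattus norvegicus) for metabolic stability, using equilibrium dialysis; a higher number here means faster removal of the compound, a lower number slower removal.
Compound 2 `CC(=O)N[C@@H]1CCC[C@H](C(=O)Nc2cc(-c3cnn4c3CCC4)c(Cl)cn2)C1` gives 72 uL/min in this assay.
Compound 3 `CC(=O)N[C@@H]1CCC[C@H](C(=O)Nc2cc(-c3cnc4n3CCC4)c(Cl)cn2)C1` gives 19 uL/min in this assay.

Compound 3 stands lowest of the three numbers. Its nearest neighbour is compound 1, whose value lies within the scatter of compound 3's, so no order can be drawn between those two; compound 2 sits furthest away, beyond the scatter.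

Compound 4 `CC(=O)N[C@@H]1CCC[C@H](C(=O)Nc2cc(-c3cnn4c3OCCC4)c(Cl)cn2)C1` differs from compound 3 in one place: a group of 9 heavy atoms (6 carbon, 2 nitrogen, 1 oxygen; one five-membered aromatic ring with 2 hetero atoms, one six-membered non-aromatic ring with 2 hetero atoms) in place of a group of 8 heavy atoms (6 carbon, 2 nitrogen; one five-membered non-aromatic ring with 1 hetero atom, one five-membered aromatic ring with 2 hetero atoms), on an aromatic carbon

Within the data shown here, only one measured step bears on this change. It is a 3.8-fold lower number from compound 2 to compound 3 (0.58 log units; beyond the scatter), and it also exchanged one fused bicyclic group for another at the same aromatic carbon of the same chlorinated core. That step shows that swapping the bicycle here can shift the number modestly and beyond the scatter. Among the measured compounds shown here, no measured pair shows the direction for the group entering in compound 4, so the sign of the step is open; the account therefore expects a step of a 1.8-fold higher number from compound 3 to compound 4 (0.27 log units; within the scatter), with a wide range. Compound 4 is expected to give 35 uL/min, estimated between 14 uL/min and 90 uL/min.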

Compound 4, intrinsic clearance in a liver preparation (reported as CLH), per the amount of preparation that the assay uses: 34 uL/min
Estimate against measurement, compound 4: 1.0-fold (0.01 log units) above; the range from low to high includes it.
By their numbers in this assay, from the lowest: compounds 3, 1 and 4 (each within the scatter of the next); then compound 2.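

In this assay, the exchange of the five-membered non-aromatic ring for the larger six-membered non-aromatic ring carrying an oxygen gives a 1.8-fold higher number from compound 3 to compound 4 (0.25 log units; within the scatter) and so sets no order between these two groups on the chlorinated core. The same entering group, set against the group of compound 2, gives a 2.1-fold lower number from compound 2 to compound 4 (0.33 log units; beyond the scatter) and thus a modest separation, so that of the three bicyclic groups at this aromatic carbon, opposite the ring nitrogen, the group of compound 2 alone stands apart from the other two. The measured values give no reason for these differences.

Compound 4 differs from compound 2 in both ring size and the added oxygen, so the compounds shown leave open which of these two features goes with the modest separation. Also open, on these data alone, is whether an amine nitrogen in place of the ring oxygen, or a fluoro group in place of the chloro group, would leave the number within the scatter of compound 3.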